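The compounds below may be only part of what the source reports. "The series", "measured", "known", "first", "only" and "open" are said of these compounds alone.

The measured compounds in an ADME assay on RAW264.7 cells (Mus musculus) for cytotoxicity, read by MTT assay, with a stated time of 48 h; on this read-out higher numbers stand for lower toxicity in this test and lower numbers for higher toxicity in this test:

Compound 1, `CC(=O)OC[C@H]1O[C@H](OC[C@@H](Cn2cc(CN(c3nc(-c4ccc([N+](=O)[O-])cc4)no3)C3CCCCC3)nn2)OC(C)=O)C=C[C@@H]1OC(C)=O`, gives 64.1 ug/mL.
Compound 2, `C#CCN(c1nc(-c2ccc(OC)cc2)no1)C1CCCCC1`, gives 28 ug/mL.
Compound 3, `COc1ccc(-c2noc(N(Cc3cn(C[C@H](CO[C@@H]4C=C[C@H](OC(C)=O)[C@@H](COC(C)=O)O4)OC(C)=O)nn3)C3CCCCC3)n2)cc1`, gives 86.3 ug/mL.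

Compound 1 and compound 3 share a large core and differ in one place: nitro in place of methoxy on an aromatic carbon. That change gave the step of a 1.3-fold lower number from compound 3 to compound 1 (0.13 log units; within the scatter). Compound 2 carries a different core; how its core differs from that of compound 3 is not broken down here. Compound 2 gives the lowest number of the three, and its gaps to compound 1 and to compound 3 both lie beyond the usual scatter.

Compound 4, `C#CCN(c1nc(-c2ccc([N+](=O)[O-])cc2)no1)C1CCCCC1`, has not yet been measured. It differs from compound 2 by nitro in place of methoxy on an aromatic carbon, the same change that leads from compound 3 to compound 1. That earlier step stayed within the scatter. On that basis a step of similar size is expected here, a 1.2-fold lower number from compound 2 to compound 4 (0.07 log units; within the scatter), because the earlier step of a 1.3-fold lower number from compound 3 to compound 1 (0.13 log units; within the scatter) was small. Compound 4 is therefore estimated at 24 ug/mL, with the expected range running from 12 ug/mL to 48 ug/mL.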

Compound 4, half-maximal cytotoxic concentration: 26.7 ug/mL
For compound 4 the middle estimate is 1.1-fold (0.05 log units) below the measured one, within the range that was stated.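

In this assay, putting nitro in place of methoxy on the aromatic carbon gives a 1.0-fold lower number from compound 2 to compound 4 (0.02 log units; within the scatter), so on this small core the swap leaves no readable difference in the test. Set beside the same swap on the larger core, this step agrees with the earlier one, which means that in this series the result carries over from one core to the other: the same change on two cores in this assay, a 1.3-fold lower number (0.13 log units; within the scatter) from compound 3 to compound 1 and a 1.0-fold lower number (0.02 log units; within the scatter) from compound 2 to compound 4, 1.3-fold (0.11 log units) apart, within the scatter of two such steps. Among the compounds shown here, this is only two pairs in a single cell test, so it does not show that the swap would behave the same way on every core or in any other test, and it gives no reason why the two groups read alike.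

The compounds shown carry only methoxy or nitro at this place, so it remains open whether an amine or a carboxylic acid there would move the number beyond the scatter in this assay. On these data alone, it also remains open whether the swap would stay this small on a third core, for example one bearing a longer chain.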